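The source may report more compounds than this note shows. Statements on the series, on what has been measured and on what is new or still open speak of the compounds shown alone.

Working notes on the series. Within the data shown here, the shared core carries a (1H-indol-3-yl)sulfanyl group and a (phenylcarbamoyl)amino group; the two measured members are compound 1 `O=C(Nc1ccccc1)Nc1nc(Nc2ccccc2)cc(Sc2c[nH]c3ccccc23)n1` and compound 2 `O=C(Nc1ccccc1)Nc1nc(Nc2ccc(Cl)cc2)cc(Sc2c[nH]c3ccccc23)n1`. In a functional assay on PC-3 cells (Homo sapiens) for inhibition, with a stated time of 72 h (a lower number here means a stronger inhibitor, a higher number a weaker inhibitor), compound 1 gives 26400 nM. In this assay compound 2 gives 32300 nM, the highest of the two numbers, with compound 1 nearest; the step of a 1.2-fold higher number from compound 1 to compound 2 (0.09 log units; within the scatter) lies within the scatter, so the two stand level.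

Compound 3 `O=C(Nc1ccccc1)Nc1nc(Sc2c[nH]c3ccccc23)cc(N2CCCCC2)n1` is not yet measured. It differs from compound 2 by piperidin-1-yl in place of (4-chlorophenyl)amino on an aromatic carbon. Among the measured compounds shown here, the only measured step, a 1.2-fold higher number from compound 1 to compound 2 (0.09 log units; within the scatter), concerns a chloro in place of hydrogen on an aromatic carbon and does not bear on an exchange of the whole (4-chlorophenyl)amino group for piperidin-1-yl; no measured pair shows this kind of change. With nothing to point in either direction, no step beyond the scatter is expected in this assay, though the range must be kept wide.

For compound 3 the expected value in this assay is 30000 nM, within 8000 nM to 110000 nM. This estimate means a step of a 1.1-fold lower number from compound 2 to compound 3 (0.03 log units; within the scatter) from compound 2, expected to stay within the scatter.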

Compound 3, half-maximal inhibitory concentration: 12100 nM
The estimate for compound 3 lay 2.5-fold (0.39 log units) above the measured number; the range from low to high includes it.
By their numbers in this assay, from the lowest: compound 3; then compounds 1 and 2 (each within the scatter of the next).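

At the aromatic carbon next to the ring nitrogen, the earlier pair varied only a chloro on the anilino ring, whereas exchanging the entire substituent moves the number in this assay, with a 2.7-fold lower number from compound 2 to compound 3 (0.43 log units; beyond the scatter) and a 2.2-fold lower number from compound 1 to compound 3 (0.34 log units; beyond the scatter) as the two steps. This position therefore responds to the nature of the attached group, although both steps are modest and rest on a single compound, compound 3. Piperidin-1-yl differs from the (4-chlorophenyl)amino group in both its non-aromatic ring and its 0 hydrogen-bond donors, and nothing at hand separates these two differences or gives a reason for the step.

Going by these compounds, whether any non-aromatic ring serves here, or whether the absence of the amino hydrogen is enough, remains open, and morpholin-4-yl, pyrrolidin-1-yl or an open-chain diethylamino group at this place would bear on that question. On these data alone, the (1H-indol-3-yl)sulfanyl and (phenylcarbamoyl)amino groups are also the same in all three compounds, so it remains unknown whether the step would hold with a different group at either of those places.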